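This account rests on a few compounds, and the source may have more. Where it says the series, first, only, none or still open, it means among the compounds named here.

The measured compounds:

Compound 1, `COc1cc(OC)c2c(c1)C(C(O)c1ccc(OCc3ccccc3)cc1)OC2=O`: > 10000 nM
Compound 2, `COc1cc(OC)c2c(c1)C(C(O)c1ccc(OCc3ccc(F)cc3)cc1)OC2=O`: 760 nM
Compound 3, `COc1cc(OC)c2c(c1)/C(=C/c1ccc(OCc3ccccc3)cc1)OC2=O`: > 10000 nM

In a functional assay on RAW264.7 cells (Mus musculus) for inhibition, read by Griess assay, with stated times of 1 h and 24 h (on this read-out higher numbers stand for weaker inhibition and lower numbers for stronger inhibition), compound 1 gives no number but a limit of the assay, > 10000 nM. Compound 2 gives 760 nM in this assay. The change from compound 1 to compound 2 is fluoro in place of hydrogen on an aromatic carbon, and it made the step of an at least 13-fold lower number from compound 1 to compound 2 (1.11 log units; beyond the scatter). Compound 3 also gives only a limit of the assay, > 10000 nM. The difference between the cores of compound 1 and compound 3 is not broken down here. Among the compounds with values here, compound 4, `COc1cc(OC)c2c(c1)/C(=C/c1ccc(OCc3ccc(F)cc3)cc1)OC2=O`, is not yet measured; it differs from compound 3 by fluoro in place of hydrogen on an aromatic carbon, the same change in the same kind of place as the one made from compound 1 to compound 2.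

For compound 4 the expected step in this assay is an at least 6.6-fold lower number from compound 3 to compound 4 (0.82 log units; beyond the scatter), which rests on an at least 13-fold lower number from compound 1 to compound 2 (1.11 log units; beyond the scatter) and on the fact that compound 3 sits at the same limit as compound 1, (the limit of > 10000 nM in this assay, at which 2 of the 3 values shown sit). The estimate for compound 4 in this assay is 1500 nM, expected to fall between 400 nM and 10000 nM.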

Compound 4, half-maximal inhibitory concentration: > 10000 nM
Compound 4: only a limit was reported (the forecaster's own chance of this, stated with the estimate: 30%); at least 6.6-fold (0.82 log units) between middle value and limit.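

In this assay compound 4 gives > 10000 nM as a limit of the assay. No step can be read between compound 3 and compound 4, as both sit at one limit: the limit of > 10000 nM in this assay, at which 3 of the 4 values shown sit. The compounds shown leave open whether fluoro in place of hydrogen changes anything on the core of compound 3, as it did on the core of compound 1.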